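This account rests on a few compounds, and the source may have more. Where it says the series, first, only, none or still open, it means among the compounds named here.

Going by the values given here, compound 2 (`CN1CCC(c2c[nH]c3ccc(NC(=O)c4ccc(C#N)cc4)nc23)CC1`) gives the lowest of the two numbers so far in an assay for binding affinity to 5-hydroxytryptamine receptor 1F (Homo sapiens), read by radioligand binding (a higher number here means a weaker inhibitor, a lower number a stronger inhibitor), at 7.2 nM. Compound 1 (`CN1CCC(c2c[nH]c3ccc(NC(=O)C4CCCCC4)nc23)CC1`), which carries a cyclohexyl on the carbonyl carbon instead, gives 20 nM. Among the compounds with values here, the one measured step, a 2.8-fold lower number from compound 1 to compound 2 (0.44 log units; beyond the scatter), came from 4-cyanophenyl in place of cyclohexyl on a carbonyl carbon. Compound 3 (`Cc1ccc(C(=O)Nc2ccc3[nH]cc(C4CCN(C)CC4)c3n2)cc1`) differs from compound 2 by methyl in place of cyano on an aromatic carbon. That measured step changed the whole ring on the carbonyl carbon, not a substituent on the aromatic ring, so it bears only loosely on the change to compound 3; nothing measured here varies that substituent. The step is therefore expected to be small, either way, most likely a modest rise in the number toward that of compound 1, expressed as a 1.7-fold higher number from compound 2 to compound 3 (0.22 log units; within the scatter). Compound 3 is expected to give about 12 nM in this assay, within a range of 4 nM to 40 nM.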

Compound 3, inhibition constant: 12 nM
Estimate against measurement, compound 3: no gap at the digits printed, and the stated range covers the measured number.
By their numbers in this assay, from the lowest: compounds 2, 3 and 1 (each within the scatter of the next, the first and the last beyond it).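

In this assay, the exchange of cyano for methyl on the aromatic carbon para to a large group gives a step within the scatter (a 1.7-fold higher number from compound 2 to compound 3 (0.22 log units; within the scatter)), although the group that leaves has a hydrogen-bond acceptor and the group that enters has none. The step from cyclohexyl to 4-methylphenyl on the carbonyl carbon also lies within the scatter (a 1.7-fold lower number from compound 1 to compound 3 (0.22 log units; within the scatter)), so the step beyond the scatter seen with 4-cyanophenyl (a 2.8-fold lower number from compound 1 to compound 2 (0.44 log units; beyond the scatter)) does not recur with this other aromatic group. Nothing available accounts for these numbers.

As far as these compounds go, whether an amine, a methoxy group, a carboxylic acid or a fluorine on that same aromatic carbon would give a step beyond the scatter remains open. So does the number for a phenyl carrying no group there.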